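A few compounds are considered here, and "the series" means these few. Any claim that something is new, unique, unknown or untested is made for them only; others in the source may bear on it.

Among the compounds with values here, compound 3 `CC(C)=CCOc1c(C)c(C)c2c(c1C)CCC(C)(COc1ccc(/C=C3\SC(=O)NC3=O)cc1C)O2` gives 89% in a functional assay on MCF7 cells (Homo sapiens), tested at 2.5 uM (a lower number here means a stronger effect, a higher number a weaker effect of the compound at the concentration tested), the lowest of the three numbers so far; compound 1 `CCOc1cc(/C=C2\SC(=O)NC2=O)ccc1OCC1(C)CCc2c(C)c(OCC=C(C)C)c(C)c(C)c2O1` gives 107% and compound 2 `Cc1c(C)c2c(c(C)c1OC(=O)CCC(=O)O)CCC(C)(COc1ccc(/C=C3\SC(=O)NC3=O)cc1)O2` gives 115%. Within the data shown here, the only measured step on the shared core, a number 18 percentage points lower from compound 1 to compound 3 (beyond the scatter), is the one case of a change on an aromatic carbon. Compound 4 `CC(C)=CCOc1c(C)c(C)c2c(c1C)CCC(C)(COc1ccc(/C=C3\SC(=O)NC3=O)cc1F)O2` differs from compound 3 by fluoro in place of methyl on an aromatic carbon. Among the measured compounds shown here, no measured step swaps methyl for fluoro, so the expectation rests on this being a one-heavy-atom-for-one-heavy-atom change, smaller than the change behind a number 18 percentage points lower from compound 1 to compound 3 (beyond the scatter): the step of a number 1 percentage points higher from compound 3 to compound 4 (within the scatter) is expected to be small, within the scatter or slightly downward. Compound 4 is therefore estimated at 90% in this assay, with a range from 78% to 104%.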

Compound 4, a percentage reported as activity, at one concentration (the size of the read-out at that concentration, not a potency): 95%
Estimate against measurement, compound 4: 5 percentage points below, within the range that was stated.
By their numbers in this assay, from the lowest: compounds 3 and 4 (each within the scatter of the next); then compounds 1 and 2 (each within the scatter of the next).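

At this aromatic carbon, ortho to a large group, fluoro and methyl cannot be told apart in this assay (a number 6 percentage points higher from compound 3 to compound 4 (within the scatter)). Fluoro in place of ethoxy also gives a step beyond the scatter (a number 12 percentage points lower from compound 1 to compound 4 (beyond the scatter)), so both one-atom groups on the shared core separate from ethoxy. Going by these compounds, whether an amine, a carboxylic acid or a longer chain at this carbon would shift the number further stays open. Nothing measured here explains these steps.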